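Cytotoxicity notes: from compound 3 to compound 4

The source may hold more compounds than are shown below. What is called first, only, known or untested is meant among the compounds shown, and "the series" means these compounds.

For the measured compounds named here, in an ADME assay on H1-HeLa cells (Homo sapiens) for cytotoxicity, read by MTT assay, with a stated time of 3 days (on this read-out lower numbers stand for higher toxicity in this test and higher numbers for lower toxicity in this test), compound 3 (`CCc1nc(-c2ccc(Oc3ccnc(C(=O)NC)c3)cc2)no1`) gives 43700 nM, the only true number in the set. Compound 1 (`CNC(=O)c1cc(Oc2ccc3c(C)c(-c4noc(C)n4)sc3c2)ccn1`) gives > 100000 nM, which is a limit of the assay and not a number. Compound 2 (`CNC(=O)c1cc(Oc2ccc3c(C)c(-c4noc(C(F)(F)F)n4)sc3c2)ccn1`) gives > 100000 nM, likewise a limit and not a number. The remaining data therefore reduce to the limit of > 100000 nM in this assay, at which 2 of the 3 values shown sit.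

Compound 4 (`CNC(=O)c1cc(Oc2ccc(-c3noc(CC(C)C)n3)cc2)ccn1`) differs from compound 3 by one change, (isopropyl in place of methyl on a saturated chain carbon bound to an aromatic carbon). In words, this is isopropyl in place of methyl on a saturated chain carbon bound to an aromatic carbon; cut one bond further out, it reads ethyl to isobutyl.

Going by the values given here, only one measured step is available, a step that the two limits leave unreadable from compound 1 to compound 2, with trifluoromethyl in place of methyl on an aromatic carbon. It offers no size to carry over and no direction. With no readable step to scale from, the anchor remains compound 3 at 43700 nM, and no change beyond the scatter is expected in this assay. The expected move is a 1.1-fold lower number from compound 3 to compound 4 (0.04 log units; within the scatter). The estimate for compound 4 is 40000 nM, with an expected range of 15000 nM to 100000 nM.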

Compound 4, half-maximal cytotoxic concentration: 23400 nM
The estimate for compound 4 lay 1.7-fold (0.23 log units) above the measured number; the measured number falls inside the stated range.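

In this assay, for the compounds shown here, a 1.9-fold lower number from compound 3 to compound 4 (0.27 log units; within the scatter) is the first readable step, and it lies within the scatter. On a saturated chain carbon bound to an aromatic carbon, the change from ethyl to isobutyl adds carbon without a move that this read-out can separate from the scatter, so compound 3 and compound 4 count as alike in this test. Compound 4 also supplies a second true number, so the series no longer rests on a single value, while the step between the other two compounds cannot be read, since both of its ends are limits: the limit of > 100000 nM in this assay, at which 2 of the 4 values shown sit.

On these data alone, what a longer chain, a cyclopropyl ring, an amine or a carboxylic acid would do at this position in this assay remains open. A single step within the scatter also leaves open whether the same change from ethyl to isobutyl would read alike on the core of compound 1, where the values shown so far are limits and not numbers.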